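The compounds below may be only part of what the source reports. "The series", "measured", "known", "first", "only" and "open" are said of these compounds alone.

Compound 1 `CC(C)c1c(C(=O)NCc2ccccc2)nn(-c2ccc(F)cc2)c1OC[C@@H](O)C[C@@H](O)CC(=O)O` is the stronger of the two measured compounds: in an assay on microsomes from liver for inhibition of 3-hydroxy-3-methylglutaryl-coenzyme A reductase (Rattus norvegicus) (on this read-out lower numbers stand for stronger inhibition and higher numbers for weaker inhibition), compound 1 gives 3.8 nM, the lowest of the two numbers, and compound 2 `CC(C)c1c(C(=O)NCc2ccccn2)nn(-c2ccc(F)cc2)c1OC[C@@H](O)C[C@@H](O)CC(=O)O` gives 25 nM. Going by the values given here, the one measured step, a 6.6-fold higher number from compound 1 to compound 2 (0.82 log units; beyond the scatter), came from swapping pyridin-2-yl for phenyl on a saturated chain carbon bound to an amide-type nitrogen, which is a change at the aromatic ring rather than at the amide. Compound 3 `CC(C)c1c(C(=O)N(C)Cc2cccc(Cl)c2)nn(-c2ccc(F)cc2)c1OC[C@@H](O)C[C@@H](O)CC(=O)O` differs from compound 1 in a different way: (3-chlorobenzyl)(methyl)amino in place of benzylamino on a carbonyl carbon. The measured step concerns a different part of the group, so it bears on this change only loosely, by showing that alterations in this benzylamide region can move the number beyond the scatter. Loss of the hydrogen-bond donor together with the added chlorine gives no firm direction, so a modest weakening is expected for compound 3, as a 2.6-fold higher number from compound 1 to compound 3 (0.42 log units; beyond the scatter), giving an estimate of 10 nM with a range from 3 nM to 40 nM.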

Compound 3, half-maximal inhibitory concentration: 8.3 nM
Estimate against measurement, compound 3: 1.2-fold (0.08 log units) above; low and high end bracket the measured number.
By their numbers in this assay, from the lowest: compound 1; then compound 3; then compound 2.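

In this assay, putting (3-chlorobenzyl)(methyl)amino in place of benzylamino on the carbonyl carbon gives a 2.2-fold higher number from compound 1 to compound 3 (0.34 log units; beyond the scatter): a real but modest weakening, which shows that strong inhibition in this series does not depend on keeping the amide hydrogen. The same group also compares well with the pyridine-bearing amide, with a 3.0-fold lower number from compound 2 to compound 3 (0.48 log units; beyond the scatter), so this larger, chlorine-bearing group gives up less than the pyridin-2-yl swap did. No measurement here explains either shift.

On these data alone, the methyl group and the chlorine enter together, so the contribution of each remains unknown. Open too, as far as these compounds go, is how benzyl(methyl)amino, (3-chlorobenzyl)amino or a longer chain such as 2-phenylethylamino would compare on this carbonyl carbon.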